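Replacing a chloro-hydroxy ring by a dihydroxy ring

The source may hold more compounds than are shown below. What is called first, only, known or untested is meant among the compounds shown, and "the series" means these compounds.

Compound 1 `Cc1c(C(=O)N/N=C\c2ccccn2)oc2cccc(O)c12` gives >= 40000 nM in a functional assay on PC-3 cells (Homo sapiens) for inhibition; on this read-out lower numbers stand for stronger inhibition and higher numbers for weaker inhibition; this value is a limit of the assay, not a number.
Compound 2 `Cc1c(C(=O)N/N=C\c2cc(O)ccc2O)oc2cccc(O)c12` gives 95500 nM in this assay.
Compound 3 `Cc1c(C(=O)N/N=C\c2c(O)cccc2Cl)oc2cccc(O)c12` gives 18700 nM in this assay.

Of the two numbers shown, compound 3 holds the lower one; its nearest neighbour is separated from it by a 5.1-fold lower number from compound 2 to compound 3 (0.71 log units; beyond the scatter), a gap beyond the scatter. The third value, (the limit of >= 40000 nM in this assay, at which 1 of the 3 values shown sits), is a limit and so cannot be placed in this order, though an at least 2.1-fold lower number from compound 1 to compound 3 (0.33 log units; beyond the scatter) shows at least a modest drop in the same direction.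

Compound 4 `Cc1c(C(=O)N/N=C\c2cccc(O)c2O)oc2cccc(O)c12` differs from compound 3 in one place: 2,3-dihydroxyphenyl in place of 2-chloro-6-hydroxyphenyl on a carbon with a double bond to nitrogen. The step that bears most directly on this change is a 5.1-fold lower number from compound 2 to compound 3 (0.71 log units; beyond the scatter), where a dihydroxyphenyl group replaced by 2-chloro-6-hydroxyphenyl brought a modest lowering. The change to compound 4 runs the other way, putting a dihydroxyphenyl group back in place of 2-chloro-6-hydroxyphenyl, so a modest rise in the number is the expectation, though the two hydroxy groups now sit in a different pattern than in compound 2 and that pattern has not been tested. The expected step is a 2.7-fold higher number from compound 3 to compound 4 (0.43 log units; beyond the scatter). Compound 4 is therefore estimated at 50000 nM in this assay, within a range from 18000 nM to 140000 nM.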

Compound 4, half-maximal inhibitory concentration: 12200 nM
Compound 4: middle estimate off by 4.1-fold (0.61 log units), on the high side, outside the stated range (below it).
By their numbers in this assay, from the lowest: compounds 4 and 3 (each within the scatter of the next); then compound 2.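

With the two hydroxy groups arranged as 2,3-dihydroxyphenyl, a dihydroxy ring matches the chloro-hydroxy ring in this assay, with a 1.5-fold lower number from compound 3 to compound 4 (0.19 log units; within the scatter), so chlorine is not needed at this place to reach the level of compound 3. The arrangement of the hydroxy groups matters, and not just their presence: going from 2,5-dihydroxyphenyl to 2,3-dihydroxyphenyl gives a 7.8-fold lower number from compound 2 to compound 4 (0.89 log units; beyond the scatter), so two rings with the same groups in different arrangements read apart. The 2,3-dihydroxyphenyl ring also compares favourably with pyridin-2-yl, with an at least 3.2-fold lower number from compound 1 to compound 4 (0.51 log units; beyond the scatter), though compound 1 holds a limit and not a number: the limit of >= 40000 nM in this assay, at which 1 of the 4 values shown sits.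

The compounds shown leave open whether a hydroxy group on this ring is needed at all, which a ring carrying a methoxy group or an amine in its place would help to settle. Also open, going by these compounds, is whether the hydroxy group on the shared core contributes to these numbers, and whether the match between compound 3 and compound 4 holds on any other read-out.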